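Compound 3: cyclooctyl in place of pyridin-4-yl

The source may hold more compounds than are shown below. What is called first, only, known or untested is meant among the compounds shown, and "the series" means these compounds.

Measured in a functional assay on MCF7 cells (Homo sapiens) for cytotoxicity, read by WST assay, with a stated time of 72 h; a lower number here means a stronger inhibitor, a higher number a weaker inhibitor:
compound 1 `CCOc1ccc(C2(c3ccc(O)cc3)C(=O)Nc3c2ccc(F)c3F)cc1`: 11 nM
compound 2 `O=C1Nc2c(ccc(F)c2F)C1(c1ccncc1)c1ccc(O)cc1`: 37 nM

Of the two measured compounds, compound 2 has the higher number, at 37 nM, which makes it the weaker inhibitor of the pair. Going by the values given here, its nearest neighbour is compound 1, the only other measured compound.

The next compound is compound 3 `O=C1Nc2c(ccc(F)c2F)C1(c1ccc(O)cc1)C1CCCCCCC1`, which differs from compound 2 in one place: cyclooctyl in place of pyridin-4-yl on a saturated ring carbon. Cyclooctyl stands in place of pyridin-4-yl on the same saturated ring carbon, and the rest of the structure is unchanged.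

Among the compounds with values here, only one measured step bears on this place: a 3.4-fold higher number from compound 1 to compound 2 (0.53 log units; beyond the scatter). In that step pyridin-4-yl replaced 4-ethoxyphenyl. Within the data shown here, no compound with a non-aromatic ring at this place has been measured, so the guide is indirect. On the strength of that step alone, a modest move to a lower number is expected in this assay once pyridin-4-yl leaves, although a move within the scatter remains possible.

The expected change is a 2.5-fold lower number from compound 2 to compound 3 (0.39 log units; beyond the scatter). For compound 3 the estimated value is 15 nM, with an expected range of 4 nM to 60 nM.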

Compound 3, half-maximal inhibitory concentration: > 1000 nM
Compound 3: a limit, no number; the forecaster's own chance of this, stated with the estimate: 3%; middle value at least 66-fold (1.82 log units) away from the limit.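

In this assay compound 3 gives > 1000 nM, which is a limit of the assay and not a number: the limit of > 1000 nM in this assay, at which 1 of the 3 values shown sits. Cyclooctyl on this saturated ring carbon gives an at least 27-fold higher number from compound 2 to compound 3 (1.43 log units; beyond the scatter), and it also gives an at least 90-fold higher number from compound 1 to compound 3 (1.95 log units; beyond the scatter), whereas the exchange between the two aromatic groups gave only a 3.4-fold higher number from compound 1 to compound 2 (0.53 log units; beyond the scatter). This position is therefore not indifferent to the ring it carries: in these three compounds, 4-ethoxyphenyl and pyridin-4-yl both give low numbers, while the one non-aromatic ring, in compound 3, gives none that can be read.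

The compounds shown do not separate the loss of an aromatic ring from the change to an eight-membered ring, and a cyclohexyl or piperidin-4-yl group on this carbon would bear on that question. From the compounds shown here alone, how far the true value of compound 3 lies beyond its limit also stays open, so the full size of both new steps remains unknown.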